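Extending the ether on the aryl oxygen of compound 3

The source may report more compounds than this note shows. Statements on the series, on what has been measured and on what is new or still open speak of the compounds shown alone.

Compound 3 `COCOc1cc(C(C)(C)C)ccc1C/N=C(\S)NCc1ccc(NS(C)(=O)=O)cc1` gives 500 nM in a functional assay for inhibition of Vanilloid receptor (Rattus norvegicus) (on this read-out higher numbers stand for weaker inhibition and lower numbers for stronger inhibition), the lowest number of the three measured, though the gap to compound 2 `CC(C)(C)c1ccc(C/N=C(\S)NCc2ccc(NS(C)(=O)=O)cc2)c(OCc2ccccc2)c1` at 770 nM is within the scatter; compound 1 `COc1cc(C(C)(C)C)ccc1C/N=C(\S)NCc1ccc(NS(C)(=O)=O)cc1` at 2400 nM lies further off. Compound 4 `COCCOc1cc(C(C)(C)C)ccc1C/N=C(\S)NCc1ccc(NS(C)(=O)=O)cc1` differs from compound 3 by methoxymethyl in place of methoxy on a saturated chain carbon bound to an oxygen on an aromatic ring. For the measured compounds named here, the steps that bear on this site are a 4.8-fold lower number from compound 1 to compound 3 (0.68 log units; beyond the scatter) and a 3.1-fold lower number from compound 1 to compound 2 (0.49 log units; beyond the scatter), both modest, while a 1.5-fold lower number from compound 2 to compound 3 (0.19 log units; within the scatter) shows that swapping one group for another at that carbon changes little. Going from methoxy to methoxymethyl there is therefore expected to give no step beyond the scatter in this assay, no change at the digits printed from compound 3 to compound 4 (within the scatter). Compound 4 is expected at 500 nM, with a range of 200 nM to 1300 nM.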

Compound 4, half-maximal inhibitory concentration: 60 nM
For compound 4 the middle estimate is 8.3-fold (0.92 log units) above the measured one; measured number below the stated range.
By their numbers in this assay, from the lowest: compound 4; then compounds 3 and 2 (each within the scatter of the next); then compound 1.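

For the compounds shown here, this carbon is less indifferent to the group it carries than the earlier compounds suggested: methoxymethyl in place of methoxy gives an 8.3-fold lower number from compound 3 to compound 4 (0.92 log units; beyond the scatter), while the swap of phenyl for methoxy stayed within the scatter. Methoxymethyl also stands clear of the other groups, with a 13-fold lower number from compound 2 to compound 4 (1.11 log units; beyond the scatter) and a 40-fold lower number from compound 1 to compound 4 (1.60 log units; beyond the scatter), so compound 4 has the lowest number of the four. Nothing measured here accounts for this drop.

Still open, going by these compounds, is whether the chain oxygen is needed for the drop. A butoxy or 2-aminoethoxy chain in place of 2-methoxyethoxy would test this.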